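Trimethoxyphenyl pyrazole chalcones: trimming a methoxy group

A few compounds are considered here, and "the series" means these few. Any claim that something is new, unique, unknown or untested is made for them only; others in the source may bear on it.

Measured compounds:
compound 1 `COc1cc(-c2cc(/C=C/C(=O)c3ccc(N)cc3)[nH]n2)cc(OC)c1OC`, 85%
compound 2 `COc1cc(-c2cc(/C=C/C(=O)c3ccc(Cl)c(Cl)c3)[nH]n2)cc(OC)c1OC`, 91%
compound 3 `COc1ccc(C(=O)/C=C/c2cc(-c3cc(OC)c(OC)c(OC)c3)n[nH]2)cc1OC`, 80%

In a functional assay on SN12C cells (Homo sapiens) for cytotoxicity, read by sulforhodamine B assay, with a stated time of 48 h, tested at 1 uM (on this read-out higher numbers stand for a weaker effect at the one concentration tested and lower numbers for a stronger effect), compound 3 gives the lowest of the three numbers. Its difference from compound 1 is a number 5 percentage points lower from compound 1 to compound 3 (within the scatter), and from compound 2 it is a number 11 percentage points lower from compound 2 to compound 3 (beyond the scatter), while compound 1 and compound 2 differ by a number 6 percentage points higher from compound 1 to compound 2 (within the scatter). Compound 4 `COc1ccc(C(=O)/C=C/c2cc(-c3cc(OC)c(OC)c(OC)c3)n[nH]2)cc1` differs from compound 3 in hydrogen in place of methoxy on an aromatic carbon. All three measured steps also exchange the aryl group on the carbonyl carbon, and only one of them exceeds the scatter, and that modestly. The expected step of a number 4 percentage points higher from compound 3 to compound 4 (within the scatter) is therefore small, with no direction beyond the scatter to be expected. Compound 4 is estimated at 84%, within 70% to 96%.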

Compound 4, a percentage reported as activity, at one concentration (the size of the read-out at that concentration, not a potency): 91%
The estimate for compound 4 lay 7 percentage points below the measured number, and the stated range covers the measured number.
By their numbers in this assay, from the lowest: compounds 3, 1, 2 and 4 (each within the scatter of the next, the first and the last beyond it).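

In this assay, hydrogen in place of methoxy gives a number 11 percentage points higher from compound 3 to compound 4 (beyond the scatter) as a modest step, the first shown that alters a single group on the aryl ring instead of exchanging the whole aryl group. The 4-methoxyphenyl group of compound 4 does not separate from the other aryl groups, with no change at the digits printed from compound 2 to compound 4 (within the scatter) and a number 6 percentage points higher from compound 1 to compound 4 (within the scatter) both within the scatter. Nothing at hand accounts for the step. The compounds shown leave open how a hydroxyl group or a fluorine atom would read at this place, and whether the same step holds at any other concentration.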